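Purine riboside series: benzyloxy to (4-methylbenzyl)sulfanyl

This account rests on a few compounds, and the source may have more. Where it says the series, first, only, none or still open, it means among the compounds named here.

Two compounds have numbers in an assay on isolated protein for binding affinity to Equilibrative nucleoside transporter 1 (Homo sapiens); a lower number here means a stronger inhibitor, a higher number a weaker inhibitor. Compound 1 `O=[N+]([O-])c1cccc2c1CCN(c1ncnc3c1ncn3[C@@H]1O[C@H](CO)[C@@H](O)[C@H]1O)C2` gives 3020 nM. Compound 2 `OC[C@H]1O[C@@H](n2cnc3c(OCc4ccccc4)ncnc32)[C@H](O)[C@@H]1O` gives 2090 nM, the lower of the two numbers, though its gap to compound 1 is within the scatter, so no order between the two can be stated. Compound 3 `Cc1ccc(CSc2ncnc3c2ncn3[C@@H]2O[C@H](CO)[C@@H](O)[C@H]2O)cc1` has not yet been measured. Compared with compound 2 the change is (4-methylbenzyl)sulfanyl in place of benzyloxy on an aromatic carbon. Going by the values given here, no pair of measured compounds differs by a change of this kind, so there is no measured step to lean on; the estimate rests on compound 2 at 2090 nM and on the change itself. Among the compounds with values here, for compound 3 the expectation is a downward step beyond the scatter, a 7.0-fold lower number from compound 2 to compound 3 (0.84 log units; beyond the scatter), and the range is kept wide since no comparable measured step exists. The number estimated for compound 3 is 300 nM, between 30 nM and 3000 nM.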

Compound 3, half-maximal inhibitory concentration: 457 nM
For compound 3 the middle estimate is 1.5-fold (0.18 log units) below the measured one, within the range that was stated.
By their numbers in this assay, from the lowest: compound 3; then compounds 2 and 1 (each within the scatter of the next).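

In this assay, (4-methylbenzyl)sulfanyl in place of benzyloxy on this aromatic carbon gives a 4.6-fold lower number from compound 2 to compound 3 (0.66 log units; beyond the scatter), so the number responds to a change at this position in a way the earlier values could not show. The change combines two edits, sulfur for the linking oxygen and a 4-methyl on the benzyl group, and this single step does not apportion the drop between them. Nothing available here accounts for the size of the step.

Still open, on these data alone, is which edit carries the step, a question that unsubstituted benzylsulfanyl and (4-methylbenzyl)oxy would help to separate. Also open, as far as these compounds go, is how this position responds to an amine linker, as in benzylamino, or to a longer chain, as in 2-phenylethylsulfanyl.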